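Swapping the nitrogen substituent: a cyclopropyl analogue

The compounds below may be only part of what the source reports. "The series", "measured", "known", "first", "only" and "open" are said of these compounds alone.

Of the compounds shown here, three sharing one core have been measured in an assay on HEK-293T cells for antagonist activity at vitamin D3 receptor (Homo sapiens), read by a luciferase reporter, with a stated time of 24 h; on this read-out higher numbers stand for weaker inhibition and lower numbers for stronger inhibition. Compound 1 `CCC(CC)n1c(-c2ccc(OCc3c(-c4c(Cl)cccc4Cl)noc3C(C)C)cc2)nc2ccc(C(=O)O)cc21` gives 5690 nM in this assay. Compound 2 `CC(C)c1onc(-c2c(Cl)cccc2Cl)c1COc1ccc(-c2nc3ccc(C(=O)O)cc3n2CC(C)(C)C)cc1` gives 861 nM. Compound 3 `CC(=O)N1CCC(n2c(-c3ccc(OCc4c(-c5c(Cl)cccc5Cl)noc4C(C)C)cc3)nc3ccc(C(=O)O)cc32)CC1` reaches only a limit of the assay, > 10000 nM, so no number is known for it. Among the two numbers, compound 1 stands highest: a 6.6-fold lower number from compound 1 to compound 2 (0.82 log units; beyond the scatter). The other steps are an at least 1.7-fold higher number from compound 1 to compound 3 (0.24 log units; that floor lies within the scatter) and an at least 11-fold higher number from compound 2 to compound 3 (1.06 log units; beyond the scatter).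

Compound 4 `CC(C)c1onc(-c2c(Cl)cccc2Cl)c1COc1ccc(-c2nc3ccc(C(=O)O)cc3n2C2CC2)cc1` has not yet been measured. It differs from compound 1 in one place: cyclopropyl in place of pentan-3-yl on an aromatic nitrogen. All three measured steps change the group on that same aromatic nitrogen, so each of them bears on this one. Neopentyl lowered the number modestly. 1-Acetylpiperidin-4-yl, by contrast, pushed the value out to the assay limit (the limit of > 10000 nM in this assay, at which 1 of the 3 values shown sits). Cyclopropyl, like pentan-3-yl, carries no hydrogen-bond donor or acceptor, so a step of at most modest size is expected, with the direction uncertain: a 1.4-fold lower number from compound 1 to compound 4 (0.15 log units; within the scatter) is the expected step. Compound 4 is therefore expected to give about 4000 nM, within 1200 nM to 12000 nM.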

Compound 4, half-maximal inhibitory concentration: 3200 nM
Compound 4: middle estimate off by 1.3-fold (0.10 log units), on the high side; the range from low to high includes it.
By their numbers in this assay, from the lowest: compound 2; then compounds 4 and 1 (each within the scatter of the next). At a limit, above all of these: compound 3.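

Replacing the pentan-3-yl group on this aromatic nitrogen with a cyclopropyl ring, which has fewer carbons, gives no change that can be told from scatter in this assay (a 1.8-fold lower number from compound 1 to compound 4 (0.25 log units; within the scatter)). Yet the number does not depend on the mere presence of a plain carbon group here, since neopentyl in compound 2 stands apart from cyclopropyl (a 3.7-fold higher number from compound 2 to compound 4 (0.57 log units; beyond the scatter)), so carbon-only groups at this position are not interchangeable. Compound 3 stays at a limit of the assay, and even the floor of its step to the cyclopropyl analogue lies beyond the scatter (an at least 3.1-fold lower number from compound 3 to compound 4 (0.49 log units; beyond the scatter)), which sets 1-acetylpiperidin-4-yl apart from a carbon-only ring on the same nitrogen: the limit of > 10000 nM in this assay, at which 1 of the 4 values shown sits.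

On these data alone, what makes neopentyl differ from the other carbon-only groups stays open, and a straight butyl chain or a cyclobutyl ring on this nitrogen would help to place it. As far as these compounds go, it is also open whether the acetyl group or the ring of compound 3 matters more, a question that a piperidin-4-yl group with a free amine could begin to separate.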